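Chlorine Added to a Compound Already Beyond the Limit

This account rests on a few compounds, and the source may have more. Where it says the series, first, only, none or still open, it means among the compounds named here.

Compound 1, `Cc1cc(S(=O)(=O)Nc2nc3ccccc3c(=O)n2N)c(S)cc1Cl`: 15700 nM in a functional assay on SNB-19 cells (Homo sapiens) for inhibition; on this read-out higher numbers stand for weaker inhibition of growth and lower numbers for stronger inhibition of growth
Compound 2, `Cc1cc(S(=O)(=O)Nc2nc3cc(-c4ccccc4)sc3c(=O)n2Cc2ccccc2)c(S)cc1Cl`: > 100000 nM in this assay

Of the two measured compounds, only compound 1 gives a number in this assay. For compound 2 the result is a limit of this assay, not a measured number, and so compound 2 stands at the weak end of what is shown, at the limit of > 100000 nM in this assay, at which 1 of the 2 values shown sits. Going by the values given here, no pair of measured compounds differs in a single place, so nothing here shows how any one change acts on growth inhibition.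

Compound 3, `Cc1cc(S(=O)(=O)Nc2nc3cc(-c4ccc(Cl)cc4)sc3c(=O)n2Cc2ccccc2)c(S)cc1Cl`, is not yet measured. It differs from compound 2 by chloro in place of hydrogen on an aromatic carbon. For the step from compound 2 to compound 3 in this assay no change beyond the usual scatter is expected, and compound 3 is expected to remain at or past the limit, as a step that the limit leaves unreadable from compound 2 to compound 3. Compound 3 is therefore estimated at 120000 nM, in the range from 40000 nM to 400000 nM, with the measurement most likely again reported only as a limit.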

Compound 3, concentration for 50% growth inhibition: > 100000 nM
Compound 3: only a limit was reported; the forecaster's own chance of this, stated with the estimate: 75%; the middle value lies beyond the limit too.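

In this assay compound 3 gives > 100000 nM, which is a limit and not a number. Compound 2 also sits at a limit, so no step between compound 2 and compound 3 can be read: the limit of > 100000 nM in this assay, at which 2 of the 3 values shown sit.

As far as these compounds go, whether chloro in place of hydrogen changes growth inhibition at all stays open.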